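The compounds below may be only part of what the source reports. "The series", "measured", "known", "first", "only" and "open" are said of these compounds alone.

Compound 2 `CC(C)=CCC/C(C)=C/CC1Cc2c(OC(=O)Nc3ccc(F)c(Cl)c3)cc(=O)n(CCCO)c2CC1(C)C` gives 25% in a functional assay on PANC-1 cells (Homo sapiens) for inhibition, read by MTT assay, with a stated time of 24 h, tested at 10 uM; a higher number here means more inhibition at the concentration tested (going by the name of the read-out), a lower number less inhibition. Among the measured compounds shown here, of the two numbers so far, that of compound 2 is the smaller one, but the gap to compound 1 `CC(C)=CCC/C(C)=C/CC1Cc2c(OC(=O)Nc3ccc(F)cc3F)cc(=O)n(CCCO)c2CC1(C)C`, which gives 33.7%, is within the scatter. For the measured compounds named here, the single measured step, a number 8.7 percentage points lower from compound 1 to compound 2 (within the scatter), shows that exchanging one substituted phenyl for another on the amide-type nitrogen left this assay essentially where it was. Compound 3 `CC(C)=CCC/C(C)=C/CC1Cc2c(OC(=O)Nc3cccc(C(F)(F)F)c3)cc(=O)n(CCCO)c2CC1(C)C` carries the change (3-(trifluoromethyl)phenyl in place of 3-chloro-4-fluorophenyl on an amide-type nitrogen). This bears directly on the measured step, since both changes exchange the aryl group on the amide-type nitrogen while the rest of the molecule is unchanged. Going by the values given here, because the only comparable step, a number 8.7 percentage points lower from compound 1 to compound 2 (within the scatter), stayed within the scatter, no movement beyond the scatter is expected in this assay, and a number 3 percentage points higher from compound 2 to compound 3 (within the scatter) is estimated to be small. Compound 3 is therefore expected to give about 28% in this assay, within a range from 12% to 45%.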

Compound 3, a percentage reported as inhibition, at one concentration (the size of the read-out at that concentration, not a potency): 44%
The estimate for compound 3 lay 16 percentage points below the measured number, and the stated range covers the measured number.
By their numbers in this assay, from the lowest: compounds 2 and 1 (each within the scatter of the next); then compound 3.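

On the amide-type nitrogen, this assay does respond to the choice of aryl group: 3-(trifluoromethyl)phenyl in place of 3-chloro-4-fluorophenyl gives a number 19 percentage points higher from compound 2 to compound 3 (beyond the scatter), and in place of 2,4-difluorophenyl it gives a number 10.3 percentage points higher from compound 1 to compound 3 (beyond the scatter). The earlier pair had shown no movement beyond the scatter, so this place is now seen to be able to shift the read-out, although both steps are modest and compound 3 stands above the other two only among these three aryl groups. Nothing measured here speaks to why the number rose.

The compounds shown leave open whether a phenyl carrying a nitrile or a methoxy group would hold this gain. They also leave open what a cyclohexyl group or a plain alkyl chain would do in place of the aryl group.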